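The source may hold more compounds than are shown below. What is called first, only, known or untested is meant among the compounds shown, and "the series" means these compounds.

Measured in an ADME assay on HL-60 cells (Homo sapiens) for cytotoxicity, read by MTT assay, with a stated time of 24 h; a higher number here means a weaker inhibitor, a lower number a stronger inhibitor:

Compound 1 `CC(C)CCN(C)Cc1ccc(C2CCCN(C)C2)cc1`: > 50000 nM
Compound 2 `CN(Cc1ccc(Cl)cc1)Cc1ccc(C2CCCN(C)C2)cc1`: > 50000 nM
Compound 3 `CN(C/C=C/c1ccccc1)Cc1ccc(C2CCCN(C)C2)cc1`: > 50000 nM

Each of these entries is a limit and not a number. Compound 3 stands at > 50000 nM, which is a limit. It shares this position with the other two compounds, as the series rests entirely on (the limit of > 50000 nM in this assay, at which 3 of the 3 values shown sit).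

Compound 4 `CN(CCCc1ccccc1)Cc1ccc(C2CCCN(C)C2)cc1` departs from compound 3 in a single place, on a saturated chain carbon bound to an amine nitrogen: phenethyl in place of 2-phenylethenyl on a saturated chain carbon bound to an amine nitrogen. The group keeps its aromatic ring and loses the double bond outside it.

Three measured steps change the group at this same place. They are a step that the two limits leave unreadable from compound 1 to compound 3, a step that the two limits leave unreadable from compound 2 to compound 3 and a step that the two limits leave unreadable from compound 1 to compound 2. None of them has a readable size, yet all three compounds they join remain at the limit of this assay. Within the data shown here, no measured step therefore points to a change in either direction, and no step beyond the scatter is expected here. The expected change is a step that the limit leaves unreadable from compound 3 to compound 4. For compound 4 the estimated value is 60000 nM, with an expected range from 30000 nM to 100000 nM, and a report of the limit alone is the likeliest outcome.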

Compound 4, half-maximal inhibitory concentration: > 50000 nM
Compound 4 gave a limit, no number; the forecaster's own chance of this, stated with the estimate: 85%; the middle value lies beyond the limit too.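

In this assay compound 4 gives > 50000 nM, which is a limit and not a number. Its steps to compound 1, compound 2 and compound 3 cannot be read. The whole series now stands at one point: the limit of > 50000 nM in this assay, at which 4 of the 4 values shown sit.

The compounds shown leave open what the actual value of any of them is, and whether a change of group at this place alters it.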